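The source may report more compounds than this note shows. Statements on the series, on what has been measured and on what is new or still open speak of the compounds shown alone.

Measured so far in a functional assay on Raji cells (Homo sapiens) for cytotoxicity, with a stated time of 72 h; a lower number here means that less compound is needed, a higher number that more compound is needed for the effect:
- compound 1 `C=C[C@@](C)(/C=C/c1ccc(O)cc1)CCC1OC1(C)C`: > 22500 nM
- compound 2 `C=C[C@@](C)(/C=C/c1ccc(O)cc1)CC/C=C/C(=O)OCC`: > 26000 nM
- compound 3 `C=C[C@@](C)(/C=C/c1ccc(Nc2ccc(OC(F)(F)F)cc2)cc1)CCC=C(C)C`: > 26000 nM

All three entries are limits, not numbers. Compound 3 gives only a limit, > 26000 nM. It sits with compound 2 at the limit of > 26000 nM in this assay, at which 2 of the 3 values shown sit. Compound 1 stands alone at the limit of > 22500 nM in this assay, at which 1 of the 3 values shown sits.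

The next compound, compound 4 `C=C[C@@](C)(/C=C/c1ccc(Nc2ccc(C(F)(F)F)cc2)cc1)CCC=C(C)C`, differs from compound 3 in one place: trifluoromethyl in place of trifluoromethoxy on an aromatic carbon. Trifluoromethyl takes the place of trifluoromethoxy on an aromatic carbon.

Going by the values given here, only one measured step exists, a step that the two limits leave unreadable from compound 1 to compound 2. It lies on the chain rather than on the aromatic ring, and it has no readable size to carry over. No step beyond the scatter is therefore expected in this assay, in either direction, because compound 3 gives > 26000 nM and offers no number to move from. The expected change is a number no higher from compound 3 to compound 4 (the limit leaves the size open). Compound 4 will most likely also return only a limit. For compound 4 the estimated value is 26000 nM, with an expected range from 12000 nM to 40000 nM.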

Compound 4, half-maximal effective concentration: > 26000 nM
Compound 4: no number, only a limit; the forecaster's own chance of this, stated with the estimate: 75%; the middle value lies on the limit itself.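

In this assay compound 4 gives only a limit, > 26000 nM. Compound 3 also gives only a limit, > 26000 nM. No step can be read between compound 3 and compound 4. The compounds shown leave open whether trifluoromethyl and trifluoromethoxy differ at all in this assay.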